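Trimming the Hydroxylated Side Chain of Compound 1

The source may report more compounds than this note shows. Statements on the series, on what has been measured and on what is new or still open speak of the compounds shown alone.

Measured so far:
compound 1, `OCC(O)Cn1nc2c(Br)c(Br)c(Br)c(Br)c2n1`, 98%
compound 2, `OC(CCn1nc2c(Br)c(Br)c(Br)c(Br)c2n1)c1ccc(Br)cc1`, 10%
compound 3, `OC(CCn1nc2c(Br)c(Br)c(Br)c(Br)c2n1)c1ccccc1`, 28%

In a functional assay on MCF7 cells (Homo sapiens) for antiproliferative activity, read by MTT assay, with a stated time of 24 h, tested at 50 uM (a lower number here means a stronger effect, a higher number a weaker effect of the compound at the concentration tested), compound 1 gives 98%, the highest of the three numbers and so the weakest effect among them. Compound 3 stands nearest to it with a lower number, and compound 2 sits furthest below. Among the compounds with values here, the one step between measured compounds that differ in a single place, a number 18 percentage points higher from compound 2 to compound 3 (beyond the scatter), concerns a substituent on an aromatic ring and not the chain attached to the core.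

Compound 4, `C[C@@H](O)CCn1nc2c(Br)c(Br)c(Br)c(Br)c2n1`, is not yet measured. Compared with compound 1 it carries 2-hydroxypropyl in place of 1,2-dihydroxyethyl on a saturated chain carbon bound to an aromatic nitrogen. Within the data shown here, no measured step touches this chain, so nothing directly bears on the change; compounds 2 and 3 only show that much larger side chains carrying an aromatic ring go with far lower numbers, whereas compound 4 keeps a short chain of the same size as compound 1.

The step is therefore expected to stay within the scatter, with a number 8 percentage points lower from compound 1 to compound 4 (within the scatter) as the estimate. Compound 4 is expected to give about 90% in this assay, between 72% and 100%.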

Compound 4, a percentage reported as activity, at one concentration (the size of the read-out at that concentration, not a potency): 102%
Compound 4: middle estimate off by 12 percentage points, on the low side; measured number outside the range, above it.
By their numbers in this assay, from the lowest: compound 2; then compound 3; then compounds 1 and 4 (each within the scatter of the next).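

Within the data shown here, replacing 1,2-dihydroxyethyl with 2-hydroxypropyl on a saturated chain carbon bound to an aromatic nitrogen gives a number 4 percentage points higher from compound 1 to compound 4 (within the scatter) in this assay, the first direct reading of a change in this short chain. The count goes from 2 hydrogen-bond donors and 2 hydrogen-bond acceptors to 1 of each, and a defined stereocentre enters, yet the read-out shows no change beyond the usual scatter; both compounds sit at the weak end of the scale, so this pair shows only that neither short chain gives a clear effect at the concentration tested, and it cannot show whether the chain matters in a compound with a stronger effect. Nothing available speaks to the reason for this result.

Still open, going by these compounds, is whether an amine or a carboxylic acid at the end of the chain, or a longer chain without an aromatic ring, would lower the number at this position. Also open, on these data alone, is whether the mirror-image form of 2-hydroxypropyl would read the same as compound 4.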